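The source may hold more compounds than are shown below. What is called first, only, known or untested is meant among the compounds shown, and "the series" means these compounds.

Series notes. The shared core of compound 1 `CCCOC(=O)C1=C(C)NC(C)=C(C(=O)OC)C1c1[nH]c(CC)nc1Cl` carries two ester chains; in an assay on ileum for inhibition of Voltage-dependent L-type calcium channel subunit alpha-1C (Cavia porcellus) (on this read-out lower numbers stand for stronger inhibition and higher numbers for weaker inhibition), compound 1 gives 0.146 nM. Compound 2 `CCCOC(=O)C1=C(C)NC(C)=C(C(=O)OCCC)C1c1[nH]c(CC)nc1Cl` gives 0.13 nM in this assay, and compound 3 `CCCOC(=O)C1=C(C)NC(C)=C(C(=O)OCC)C1c1[nH]c(CC)nc1Cl` gives 0.543 nM. Compound 3 stands highest of the three numbers: the steps of a 3.7-fold higher number from compound 1 to compound 3 (0.57 log units; beyond the scatter) and a 4.2-fold higher number from compound 2 to compound 3 (0.62 log units; beyond the scatter) both lie beyond the scatter, whereas a 1.1-fold lower number from compound 1 to compound 2 (0.05 log units; within the scatter) does not. Compound 4 `CCOC(=O)C1=C(C)NC(C)=C(C(=O)OCc2ccccc2)C1c1[nH]c(CC)nc1Cl` has not been measured; it differs from compound 3 by phenyl in place of ethyl on a saturated chain carbon bound to an oxygen next to a carbonyl group, which, read one bond further out, is propoxycarbonyl to benzyloxycarbonyl. Among the compounds with values here, no measured step places a ring on this chain. Within the data shown here, the steps that bear on it are those on the same chain carbon: lengthening by one carbon gave a 3.7-fold higher number from compound 1 to compound 3 (0.57 log units; beyond the scatter), and shortening by one carbon gave a 4.2-fold higher number from compound 2 to compound 3 (0.62 log units; beyond the scatter), so a change here moves this assay by a modest amount, and the number for compound 3 is the outlier among the three. From the compounds shown here alone, a move back toward lower numbers is expected because compound 2 gives 0.13 nM, but a larger group is untested. Compound 4 is therefore estimated at 0.2 nM, within 0.05 nM to 0.8 nM. The expected step is a 2.7-fold lower number from compound 3 to compound 4 (0.43 log units; beyond the scatter).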

Compound 4, half-maximal inhibitory concentration: 2.66 nM
Compound 4: the middle estimate sits 13-fold (1.12 log units) below what was measured; measured number outside the range, above it.
By their numbers in this assay, from the lowest: compounds 2 and 1 (each within the scatter of the next); then compound 3; then compound 4.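

In this assay, propyl to benzyl on the ester gives a 4.9-fold higher number from compound 3 to compound 4 (0.69 log units; beyond the scatter) and puts compound 4 at the top of the four numbers, so a six-membered aromatic ring on this saturated chain carbon weakens inhibition, at least from compound 3. The earlier steps shown here changed only saturated chains, and here the first ring-bearing group moves the number the same way and by a similarly modest amount, while inhibition stays measurable at 2.66 nM for compound 4. Nothing available explains the direction or the size of this step.

Still open, from the compounds shown here alone, is whether the rise belongs to the aromatic ring or simply to a larger group, which a butyl or cyclohexylmethyl chain would help separate. Also open, going by these compounds, is how this chain responds to a phenethyl group or to a chain ending in an amine.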